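A few compounds are considered here, and "the series" means these few. Any claim that something is new, unique, unknown or untested is made for them only; others in the source may bear on it.

Compound 1 `Oc1ccc(-c2cc(-c3ccc(Cl)cc3)nc(-c3cccs3)c2)cc1` and compound 2 `Oc1ccc(-c2cc(-c3ccc(Cl)cc3)nc(-c3ccsc3)c2)cc1` share a core that carries a 4-chlorophenyl group and a 4-hydroxyphenyl group. In a functional assay on DU-145 cells (Homo sapiens) for cytotoxicity, read by CCK-8 assay and cell counting, with a stated time of 2 days (on this read-out lower numbers stand for stronger inhibition and higher numbers for weaker inhibition), compound 1 gives 7660 nM, and in the same run compound 2 gives 6940 nM. The two differ in the thiophene alone: thiophen-2-yl in place of thiophen-3-yl on an aromatic carbon. The step of a 1.1-fold higher number from compound 2 to compound 1 (0.04 log units; within the scatter) is small and the two numbers are not separable.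

Compound 3 `Oc1cccc(-c2cc(-c3ccsc3)nc(-c3cccc(Cl)c3)c2)c1` carries a 3-chlorophenyl group and a 3-hydroxyphenyl group. In this assay compound 3 gives 3330 nM, the lowest of the three numbers, and its distance from compound 2 as well as from compound 1 lies beyond the scatter. How the core of compound 3 differs from the core of compound 2 is not broken down here.

Compound 4 `Oc1cccc(-c2cc(-c3cccc(Cl)c3)nc(-c3cccs3)c2)c1` has not yet been measured. It stands to compound 3 as compound 1 stands to compound 2: thiophen-2-yl in place of thiophen-3-yl on an aromatic carbon. The surroundings of the place are not identical, since in compound 2 the group sits meta to a 4-chlorophenyl group and meta to a 4-hydroxyphenyl group, whereas in compound 3 it sits meta to a 3-chlorophenyl group and meta to a 3-hydroxyphenyl group; this is the same kind of change, not the same change.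

For the measured compounds named here, the step from compound 3 to compound 4 is expected to be of about the size a 1.1-fold higher number from compound 3 to compound 4 (0.02 log units; within the scatter), a near-nil movement, because a 1.1-fold higher number from compound 2 to compound 1 (0.04 log units; within the scatter) lies within the scatter and that is the only measured instance of this change. The estimate for compound 4 in this assay is 3500 nM, expected to fall between 1700 nM and 7200 nM.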

Compound 4, half-maximal inhibitory concentration: 2650 nM
Compound 4: middle estimate off by 1.3-fold (0.12 log units), on the high side; measured number inside the range.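

In this assay, thiophen-2-yl in place of thiophen-3-yl gives a 1.3-fold lower number from compound 3 to compound 4 (0.10 log units; within the scatter), and set beside the earlier instance of the change, the step on this core does not differ from it: the same change on two cores in this assay, a 1.1-fold higher number (0.04 log units; within the scatter) from compound 2 to compound 1 and a 1.3-fold lower number (0.10 log units; within the scatter) from compound 3 to compound 4, 1.4-fold (0.14 log units) apart, within the scatter of two such steps.
The swap between the two thiophene attachments therefore stays near nil on both cores shown, so within this pair of cores the change carries across without a readable movement in either direction. For the compounds shown here, this does not show that the two thiophenes are interchangeable on every core of the series or in any other read-out, and with only two pairs in one cell line it cannot exclude a small effect hidden inside the scatter.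

Still open is how the 3-chlorophenyl and 3-hydroxyphenyl groups each contribute on their own, as the compounds shown always pair 3-chlorophenyl with 3-hydroxyphenyl and 4-chlorophenyl with 4-hydroxyphenyl, so neither group can be read separately from the other. Also open, as far as these compounds go, is whether a ring other than thiophene at this place, such as furan-2-yl or pyridin-3-yl, would move the number beyond the scatter, or whether this place tolerates any such replacement as quietly as it tolerates the swap between the two thiophenes.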